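The source may hold more compounds than are shown below. What is called first, only, known or untested is meant among the compounds shown, and "the series" means these compounds.

Compound 1 `COc1cc(C(=O)N/N=C/c2ccccc2C(F)(F)F)cc(OC)c1OC` gives 22.1% in a functional assay on BGC-823 cells (Homo sapiens) for antiproliferative activity, read by MTT assay, tested at 1 uM; on this read-out lower numbers stand for a weaker effect and higher numbers for a stronger effect at the one concentration tested. Compound 2 `COc1ccc(OC)c(C2OC(c3cc(OC)c(OC)c(OC)c3)=NN2C(C)=O)c1` gives 0.4% in this assay, the lower of the two numbers, with compound 1 standing higher by a gap beyond the usual scatter. Compound 3 `COc1cc(C2=NN(C(C)=O)C(c3ccccc3F)O2)cc(OC)c1OC` differs from compound 2 in one place: 2-fluorophenyl in place of 2,5-dimethoxyphenyl on a saturated ring carbon. For the measured compounds named here, no step between the two measured compounds is available, so nothing measured points to the size of this change. The step of a number 7.6 percentage points higher from compound 2 to compound 3 (within the scatter) is expected to be small and upward, at the edge of the scatter. Compound 3 is estimated to give 8% in this assay, within a range from 0% to 30%.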

Compound 3, a percentage reported as inhibition, at one concentration (the size of the read-out at that concentration, not a potency): 29.6%
Beside the measured number, compound 3's estimate is 21.6 percentage points below it; measured number inside the range.
By their numbers in this assay, from the lowest: compound 2; then compounds 1 and 3 (each within the scatter of the next).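

In this assay, putting 2-fluorophenyl in place of 2,5-dimethoxyphenyl on the saturated ring carbon gives a number 29.2 percentage points higher from compound 2 to compound 3 (beyond the scatter), so the read-out at this position depends on which aryl group it carries. This single step cannot separate the loss of the methoxy groups from the gain of the fluorine. No measured evidence here accounts for the step.

Going by these compounds, it remains open how a plain phenyl or a 2-chlorophenyl on this carbon would read, and whether either would stand nearer compound 2 or compound 3.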